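From methylsulfonyl to cyano in a cell assay

The source may hold more compounds than are shown below. What is called first, only, known or untested is meant among the compounds shown, and "the series" means these compounds.

compound 1 `CS(=O)(=O)c1ccc(-c2nc3ccccn3c2Sc2ccccc2)cc1` at 72700 nM
compound 2 `COc1ccc(-c2nc3ccccn3c2Sc2ccccc2)cc1` at > 100000 nM (a limit of the assay, not a number)
compound 3 `c1ccc(Sc2c(-c3cccc4ccccc34)nc3ccccn23)cc1` at 69300 nM

In a functional assay on MDA-MB-231 cells (Homo sapiens) for inhibition, read by MTT assay, with a stated time of 48 h (a higher number here means a weaker inhibitor, a lower number a stronger inhibitor), compound 1 gives 72700 nM and compound 3 gives 69300 nM as its result. These two values lie within the usual scatter of each other, so neither can be ranked over the other. The result for compound 2 is only a limit, so compound 1 has just one true number to be compared with.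

Compound 4 `N#Cc1ccc(-c2nc3ccccn3c2Sc2ccccc2)cc1` keeps the core of compound 1 and carries cyano in place of methylsulfonyl. The change, counted as cyano in place of methylsulfonyl on an aromatic carbon sits on an aromatic carbon, para to a large group.

For the measured compounds named here, one measured step bears on it, since methoxy replaces methylsulfonyl at that same place in compound 2 (an at least 1.3-fold higher number from compound 1 to compound 2 (0.13 log units; that floor lies within the scatter)). From the compounds shown here alone, that step ends at a limit (the limit of > 100000 nM in this assay, at which 1 of the 3 values shown sits) and its true size remains open. With so little to go on, no step beyond the scatter is expected in this assay for the new swap. The estimated step is a 1.1-fold lower number from compound 1 to compound 4 (0.05 log units; within the scatter) and it is expected to stay small. Compound 4 is expected at 65000 nM (estimated range 30000 nM to 100000 nM).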

Compound 4, half-maximal inhibitory concentration: 17800 nM
Estimate against measurement, compound 4: 3.7-fold (0.56 log units) above; the measured number lies below the stated range.
By their numbers in this assay, from the lowest: compound 4; then compounds 3 and 1 (each within the scatter of the next). At a limit, above all of these: compound 2.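

Moving from methylsulfonyl to cyano gives a 4.1-fold lower number from compound 1 to compound 4 (0.61 log units; beyond the scatter) in this assay, so the group on this aromatic carbon can change the result by more than the scatter, which the earlier step to methoxy could not show. Cyano in place of methoxy gives an at least 5.6-fold lower number from compound 2 to compound 4 (0.74 log units; beyond the scatter), so among the three groups tried at this place, cyano gives the lowest number, with its steps to both the others beyond the scatter. The true size of that second step stays open, since the result for compound 2 is a limit and not a number: the limit of > 100000 nM in this assay, at which 1 of the 4 values shown sits.

From the compounds shown here alone, compound 4 gives 17800 nM, and whether an amine, a carboxylic acid or a single fluorine at this same place would give a still lower number remains unknown. The compounds shown also cannot separate what matters in the swap from methylsulfonyl to cyano, as the number of heavy atoms, the bonds and the hydrogen-bond acceptors all change together, and they cannot tell whether the same swap would give a step of this size on a different core.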